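The compounds below may be only part of what the source reports. "The series", "measured", "known", "first", "only" and "open" are said of these compounds alone.

Working notes on the series. Going by the values given here, in a functional assay on MCF7 cells (Homo sapiens) for inhibition, read by sulforhodamine B assay, with a stated time of 48 h (on this read-out higher numbers stand for weaker inhibition of growth and lower numbers for stronger inhibition of growth), compound 2 `COC(=O)c1sc2cc(-c3ccccc3N)cnc2c1N` gives 4200 nM, which is the only measured number in the set so far. Compound 1 `COC(=O)c1sc2cc(-c3cccnc3)cnc2c1N` carries pyridin-3-yl where compound 2 carries 2-aminophenyl. In this assay compound 1 gives > 112000 nM; this is a limit of the assay and not a number. Among the compounds with values here, the single measured step, an at least 26-fold lower number from compound 1 to compound 2 (1.42 log units; beyond the scatter), shows that exchanging the pendant ring can move the read-out strongly; its stated size rests on (the limit of > 112000 nM in this assay, at which 1 of the 2 values shown sits).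

Compound 3 `COC(=O)c1sc2cc(-c3cccc(N)c3)cnc2c1N` differs from compound 2 by 3-aminophenyl in place of 2-aminophenyl on an aromatic carbon. Within the data shown here, no measured step moves the amino group around the phenyl ring; the one recorded step exchanges the ring itself, so it bears only loosely on this change, and the direction of the step in this assay stays open. The expectation for compound 3 is a moderate rise in number, a 1.9-fold higher number from compound 2 to compound 3 (0.28 log units; within the scatter), with a wide band around it. Compound 3 is therefore estimated at 8000 nM, in a range from 2000 nM to 40000 nM.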

Compound 3, concentration for 50% growth inhibition: > 150000 nM
Compound 3 ended at the assay's limit; the forecaster's own chance of this, stated with the estimate: 10%; middle value at least 18-fold (1.27 log units) from the limit.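

Moving the amino group around the pendant phenyl ring, with the group's heavy atoms and its donor and acceptor counts unchanged, is enough to shift the read-out strongly in this assay, giving an at least 35-fold higher number from compound 2 to compound 3 (1.55 log units; beyond the scatter). Compound 3 gives > 150000 nM, which is a limit of the assay and not a number, and the stated size of the step rests on it: the limit of > 150000 nM in this assay, at which 1 of the 3 values shown sits. An aminophenyl ring at this place on the shared core is therefore not sufficient by itself for a measured number, as only 2-aminophenyl gives one among the compounds shown, while the step between compound 1 and compound 3 cannot be read, both values being limits.

Going by these compounds, it remains open whether the amino group of compound 2 is itself needed at this place or whether an unsubstituted phenyl ring would read the same way. Also open, on these data alone, is whether a hydroxyl or an aminomethyl group in place of that amino group would keep a measured number in this assay, and how far any such read-out would lie from that of compound 2.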